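Isopropyl for methyl on the aromatic oxygen of compound 2

The source may hold more compounds than are shown below. What is called first, only, known or untested is meant among the compounds shown, and "the series" means these compounds.

Three compounds on a shared core have numbers in an assay on isolated protein for inhibition of ribosomal protein S6 kinase alpha-2 (Homo sapiens), with a stated time of 150 min; on this read-out higher numbers stand for weaker inhibition and lower numbers for stronger inhibition. Compound 1 `COc1cccc(F)c1-c1cccc2nc(Nc3ccccc3)oc12` gives 1000 nM. Compound 2 `COc1cc(Nc2nc3cccc(-c4c(F)cccc4OC)c3o2)cc(OC)c1OC` gives 20 nM, and compound 3 `COc1ccc(Nc2nc3cccc(-c4c(F)cccc4OC)c3o2)cc1O[C@H]1CCNC1` gives 10 nM. On these three numbers compound 2 stands second highest; its nearest is compound 3, and the gap between them lies within the scatter, so no order is claimed between the two. Its furthest is compound 1, whose number is beyond the scatter away from compound 2, with compound 1 the weaker of that pair.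

For the measured compounds named here, the methyl on the oxygen on the aromatic ring is present unchanged in compound 1, compound 2 and compound 3, so no measured pair shows what altering it does.

Compound 4 `COc1cc(Nc2nc3cccc(-c4c(F)cccc4OC(C)C)c3o2)cc(OC)c1OC` differs from compound 2 in one place: isopropyl in place of methyl on an oxygen on an aromatic ring. With nothing measured on this change, the expectation rests only on the unchanged methyl across the three measured compounds and on the number of compound 2. A step from compound 2 to compound 4 that is modest and toward a higher number, or none beyond the scatter, is expected, estimated as a 2.5-fold higher number from compound 2 to compound 4 (0.40 log units; beyond the scatter). For compound 4 in this assay the expected value is 50 nM, with a range from 15 nM to 200 nM.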

Compound 4, half-maximal inhibitory concentration: 970 nM
For compound 4 the middle estimate is 19-fold (1.29 log units) below the measured one; measured number above the stated range.
By their numbers in this assay, from the lowest: compounds 3 and 2 (each within the scatter of the next); then compounds 4 and 1 (each within the scatter of the next).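

The methyl on an oxygen on an aromatic ring, unchanged across the three earlier compounds, now has a measured replacement: in this assay, isopropyl in its place brings a 49-fold higher number from compound 2 to compound 4 (1.69 log units; beyond the scatter). This position is therefore not indifferent to the change from methoxy to isopropoxy, at least with the rest of compound 2 held constant, and the direction of the step is toward weaker inhibition. The data offer no measurement that could account for a step of this size.

As far as these compounds go, this single pair does not show how the read-out changes between methyl and isopropyl, so it remains open whether ethyl or cyclopropyl on the same oxygen, or a free hydroxyl in place of the methoxy, would fall nearer to compound 2 or to compound 4. It also remains open whether the same exchange of methyl for isopropyl would produce a step of similar size on the structures of compound 1 and compound 3, since the change is shown in one setting only.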